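A few compounds are considered here, and "the series" means these few. Any claim that something is new, unique, unknown or untested is made for them only; others in the source may bear on it.

Measured compounds:
- compound 1, `CCCC(=O)OCSc1ccccc1C(=O)N[C@@H]1CCC[C@H]1C(N)=O`: 43.7 uM
- compound 2, `CCCC(=O)OC[Se]c1ccccc1C(=O)NCC(N)=O`: 6.8 uM

In an ADME assay on CEM-SS cells (Homo sapiens) for cytotoxicity, read by XTT assay, with a stated time of 6 days (a higher number here means that more compound is tolerated, a lower number that less compound is tolerated), compound 1 gives 43.7 uM, the highest of the two numbers shown. The nearest is compound 2, which in this assay gives 6.8 uM; that gap lies beyond the scatter, but the two structures differ in more than one place, so only the two values themselves can be read from the pair.

Compound 3, `C#CCNC(=O)CNC(=O)c1ccccc1SCOC(=O)CCC`, has not yet been measured in this assay. Its difference from compound 1 is (propargylcarbamoyl)methyl in place of 2-carbamoylcyclopentyl on an amide-type nitrogen. The core shared by compound 1 and compound 3 stays the same, and the group that enters carries the same count of hydrogen-bond donors and acceptors as the one that leaves, with a triple bond in place of the five-membered ring. Among the compounds with values here, no measured pair shows this kind of exchange, so there is no step to lean on.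

Compound 3 is expected to stay close to compound 1, with a step of a 1.5-fold lower number from compound 1 to compound 3 (0.16 log units; within the scatter) that is not expected to reach beyond the scatter. The estimate for compound 3 in this assay is 30 uM, within 12 uM to 80 uM.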

Compound 3, half-maximal toxic concentration: 95.4 uM
Compound 3: the middle estimate sits 3.2-fold (0.50 log units) below what was measured, outside the stated range (above it).
By their numbers in this assay, from the lowest: compound 2; then compound 1; then compound 3.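

In this assay, placing (propargylcarbamoyl)methyl instead of 2-carbamoylcyclopentyl on the amide-type nitrogen gives a 2.2-fold higher number from compound 1 to compound 3 (0.34 log units; beyond the scatter), so this position can move the number beyond the scatter, towards more compound tolerated, although the step is modest. The shift comes with the hydrogen-bond donor and acceptor counts unchanged, while the five-membered ring and both defined stereocentres leave and a triple bond enters, so equal counts alone do not keep the number in place. Nothing measured here accounts for the shift.

Within the data shown here, the single step cannot separate the loss of the ring and its stereocentres from the arrival of the triple bond, and it remains open which of these changes goes with the higher number. Also open, as far as these compounds go, is how the number would respond if a carboxylic acid, a primary amine or a longer saturated chain such as butyl stood in place of the propargyl end of the entering group, with the rest of compound 3 unchanged.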